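EP3 antagonists: a rearranged imidazole on the shared core

The source may hold more compounds than are shown below. What is called first, only, known or untested is meant among the compounds shown, and "the series" means these compounds.

Compound 1 `CC(C)C(Cc1ncc[nH]1)c1ccc(-c2ccc3cccc(F)c3c2)[nH]c1=O` was tested in a functional assay on CHO cells for antagonist activity at prostaglandin E2 receptor EP3 subtype (Homo sapiens), read by cAMP accumulation (on this read-out higher numbers stand for weaker inhibition and lower numbers for stronger inhibition), where compound 1 gives 76 nM. Going by the values given here, that is the higher of the two numbers known here: compound 2 `CCn1ncc2c(F)cc(-c3ccc(C(CC)(CC)c4nnc[nH]4)c(=O)[nH]3)cc21` gives 29 nM in this assay, and the gap between compound 1 and compound 2 lies beyond the scatter. Compound 3 `Cc1c[nH]c(C(c2ccc(-c3ccc4cccc(F)c4c3)[nH]c2=O)C(C)C)n1` has the same atoms as compound 1, joined differently: 4-methyl-1H-imidazol-2-yl in place of (1H-imidazol-2-yl)methyl on a saturated chain carbon bound to an aromatic carbon and a saturated chain carbon. Among the compounds with values here, no measured pair here shows such a change, so compound 3 is expected to sit close to compound 1, with the step of a 1.1-fold higher number from compound 1 to compound 3 (0.02 log units; within the scatter) within the scatter. Compound 3 is estimated at 80 nM, between 30 nM and 220 nM.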

Compound 3, half-maximal inhibitory concentration: 36 nM
For compound 3 the middle estimate is 2.2-fold (0.35 log units) above the measured one; low and high end bracket the measured number.
By their numbers in this assay, from the lowest: compounds 2 and 3 (each within the scatter of the next); then compound 1.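

In this assay the swap of (1H-imidazol-2-yl)methyl for 4-methyl-1H-imidazol-2-yl gives a 2.1-fold lower number from compound 1 to compound 3 (0.32 log units; beyond the scatter) with the counts of heavy atoms, donors and acceptors unchanged. This position therefore responds to how the same atoms are joined, not only to which atoms are present. No measurement here gives a cause for this step.

The compounds shown leave open whether the step follows from the ring sitting directly on the saturated chain carbon or from the methyl on that ring. A plain 1H-imidazol-2-yl on that carbon would separate the two, and an ethyl in place of the methyl would show how much room the ring substituent has.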